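This account rests on a few compounds, and the source may have more. Where it says the series, first, only, none or still open, it means among the compounds named here.

Working notes. The series rests on the shared core of compound 1 `CCCC/C(=C\c1cc(OC)c(OC)c(OC)c1)C(=O)N1CCC=C(Cl)C1=O`; compound 2 `COc1cc(/C=C(\C)C(=O)N2CCC=CC2=O)cc(OC)c1OC` and compound 3 `COc1cc(/C=C/C(=O)N2CCC=C(Br)C2=O)cc(OC)c1OC` are the other measured members. In a functional assay on HCT-116 cells (Homo sapiens) for cytotoxicity, read by MTT assay, with a stated time of 72 h (on this read-out lower numbers stand for stronger inhibition and higher numbers for weaker inhibition), compound 1 gives 7530 nM, the second highest of the three numbers. Compound 3 gives 7120 nM and compound 2 gives 10300 nM, both within the scatter of compound 1, so no order among the three can be read. Compound 4 `CCCC/C(=C\c1cc(OC)c(OC)c(OC)c1)C(=O)N1CCC=C(Br)C1=O` differs from compound 1 by bromo in place of chloro on a double-bonded ring carbon. Among the compounds with values here, no measured pair isolates this change. Compound 3, which carries bromo, gives 7120 nM and stands within the scatter of compound 1, so for compound 4 no step beyond the scatter is expected in either direction. The expected step is a 1.1-fold lower number from compound 1 to compound 4 (0.03 log units; within the scatter). The estimate for compound 4 is 7000 nM, in a range from 3500 nM to 14000 nM.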

Compound 4, half-maximal inhibitory concentration: 2590 nM
Compound 4: the middle estimate sits 2.7-fold (0.43 log units) above what was measured; the measured number lies below the stated range.
By their numbers in this assay, from the lowest: compound 4; then compounds 3, 1 and 2 (each within the scatter of the next).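

In this assay, bromo in place of chloro on the double-bonded ring carbon gives a 2.9-fold lower number from compound 1 to compound 4 (0.46 log units; beyond the scatter) on an otherwise unchanged structure. Within the data shown here, this single-atom exchange therefore registers at this position, which the earlier compounds, all within the scatter of one another, could not show. Nothing available explains the step. Still open, from the compounds shown here alone, is how this position responds to iodo, fluoro or a methyl group. Also open, going by these compounds, is whether bromo gives the same step when the butyl chain is replaced by a methyl group or a hydrogen.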